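The source may report more compounds than this note shows. Statements on the series, on what has been measured and on what is new or still open speak of the compounds shown alone.

Compound 2 `CCc1sc(CCc2cc(OC(C)C)cc(NCc3cc(Cl)cc(NC(=O)OC(C)C)c3)n2)nc1C` belongs to a short series in which the group on an oxygen on an aromatic ring is varied while the rest of the molecule stays the same. In an assay on cells for binding affinity to Neuropeptide Y receptor type 1 (Homo sapiens) (a lower number here means a stronger inhibitor, a higher number a weaker inhibitor), compound 2 gives 12 nM. Among the measured compounds shown here, its only measured neighbour is compound 1 `CCCCOc1cc(CCc2nc(C)c(CC)s2)nc(NCc2cc(Cl)cc(NC(=O)OC(C)C)c2)c1`, which carries a butyl on that oxygen; in this assay compound 1 gives 16 nM. The step of a 1.3-fold lower number from compound 1 to compound 2 (0.12 log units; within the scatter) lies within the scatter, so the two numbers cannot be told apart, and compound 2 simply stands alongside compound 1. Compound 3 `CCc1sc(CCc2cc(OCC3(C)CC3)cc(NCc3cc(Cl)cc(NC(=O)OC(C)C)c3)n2)nc1C` changes the same place once more: (1-methylcyclopropyl)methyl in place of isopropyl on an oxygen on an aromatic ring. For the measured compounds named here, the only measured step that bears on this position is a 1.3-fold lower number from compound 1 to compound 2 (0.12 log units; within the scatter), and it moved the number by no more than the scatter; the new group itself has no measured precedent, so the data give no direction. The expectation in this assay is therefore a step of a 1.1-fold higher number from compound 2 to compound 3 (0.03 log units; within the scatter) that stays within the scatter, with a wider range to allow for the untested group. Compound 3 is expected to give about 13 nM in this assay, within a range from 5 nM to 35 nM.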

Compound 3, half-maximal inhibitory concentration: 17 nM
The estimate for compound 3 lay 1.3-fold (0.12 log units) below the measured number; measured number inside the range.
By their numbers in this assay, from the lowest: compounds 2, 1 and 3 (each within the scatter of the next).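

In this assay, the ring-bearing group behaves like the two open-chain groups: a 1.4-fold higher number from compound 2 to compound 3 (0.15 log units; within the scatter), and a 1.1-fold higher number from compound 1 to compound 3 (0.03 log units; within the scatter). This position has now taken a branched isopropyl, a straight butyl and a (1-methylcyclopropyl)methyl, and the three values cannot be told apart. So the step from 3 to 5 heavy atoms and the addition of a three-membered ring of carbon leave no readable mark on the number here, a wider test of this position than the single step between compound 1 and compound 2 could give. No measurement is available that would explain this flat result.

From the compounds shown here alone, all three groups on this oxygen are made of carbon only, so it remains open whether an amine, a carboxylic acid or a much longer chain in this place would also stay within the scatter in this assay. The three compounds also share everything else, which leaves open whether the same flat picture would hold if the isopropyl carbamate or the chlorine elsewhere in the molecule were replaced.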